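The source may report more compounds than this note shows. Statements on the series, on what has been measured and on what is new or still open speak of the compounds shown alone.

Measured compounds:
compound 1 `CCCCCCc1ccc2nc(N)sc2c1` — 7 mg/kg
compound 2 `N=c1sc2cc(OC(F)(F)F)ccc2n1Cc1ccccc1` — > 10 mg/kg

In a functional assay on the whole organism with Rattus norvegicus as the target (on this read-out lower numbers stand for an effect already at smaller amounts and higher numbers for an effect only at larger amounts of compound), compound 1 gives 7 mg/kg. For compound 2 the position is less settled. In this assay compound 2 gives > 10 mg/kg, and that is a limit of the assay rather than a number. Among the compounds with values here, compound 2 therefore stands at the limit of > 10 mg/kg in this assay, at which 1 of the 2 values shown sits, and no pair of measured compounds differing in one place is available to give a measured step for the series.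

Compound 3 `CNCCn1c(=N)sc2cc(OC(F)(F)F)ccc21` is still to be measured in this assay. It differs from compound 2 at the saturated chain carbon bound to an aromatic nitrogen: (methylamino)methyl in place of phenyl on a saturated chain carbon bound to an aromatic nitrogen.

With compound 2 known only as a limit, the step to compound 3 rests on a single reference point. The expectation is a step from compound 2 to compound 3 of a number no higher from compound 2 to compound 3 (the limit leaves the size open), toward lower numbers, yet no larger than the ordinary scatter allows one to trust. Compound 3 is therefore estimated at 10 mg/kg in this assay, with a range from 3 mg/kg to 30 mg/kg, and a real chance that only a limit is reported again.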

Compound 3, dose for half-maximal effect: > 10 mg/kg
Compound 3 gave a limit, no number; the forecaster's own chance of this, stated with the estimate: 50%; the middle value lies on the limit itself.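

In this assay compound 2 and compound 3 are both limits of the assay rather than numbers, so no step can be read between them: the limit of > 10 mg/kg in this assay, at which 2 of the 3 values shown sit.

Still open, as far as these compounds go, is whether 2-(methylamino)ethyl in place of benzyl changes the read-out at all, and how far compound 2 and compound 3 each lie from the limit.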